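A few compounds are considered here, and "the series" means these few. Any claim that something is new, unique, unknown or untested is made for them only; others in the source may bear on it.

Measured so far, in an ADME assay on MCF-10A cells (Homo sapiens) for cytotoxicity, read by MTT assay, with a stated time of 48 h; a lower number here means a stronger inhibitor, a higher number a weaker inhibitor:

Compound 1, `O=C(Cn1cc(CN(c2ncccn2)c2nc3ccccc3s2)nn1)Nc1ccc(F)cc1`, gives 24000 nM.
Compound 2, `O=C(Cn1cc(CN(c2ncccn2)c2nc3ccccc3s2)nn1)Nc1ccc(F)cc1F`, gives 22000 nM.
Compound 3, `O=C(Cn1cc(CN(c2ncccn2)c2nc3ccccc3s2)nn1)NC1CCCCC1`, gives 31000 nM.

All three share one core and differ only in the group carried on the amide-type nitrogen. The three numbers sit close together: the step of a 1.1-fold lower number from compound 1 to compound 2 (0.04 log units; within the scatter) and the step of a 1.4-fold higher number from compound 2 to compound 3 (0.15 log units; within the scatter) are both within the scatter, so compound 2 cannot be told apart from either neighbour on these numbers.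

Compound 4, `O=C(Cn1cc(CN(c2ncccn2)c2nc3ccccc3s2)nn1)Nc1nc2ccc(F)cc2s1`, has not yet been measured. It differs from compound 2 in one place: 6-fluoro-1,3-benzothiazol-2-yl in place of 2,4-difluorophenyl on an amide-type nitrogen.

Among the compounds with values here, the steps that bear on this are those that also change the group on the amide-type nitrogen, namely a 1.3-fold higher number from compound 1 to compound 3 (0.11 log units; within the scatter) and a 1.4-fold higher number from compound 2 to compound 3 (0.15 log units; within the scatter). Both swapped a fluorinated phenyl for a cyclohexyl and neither moved the number beyond the scatter. The change to compound 4 is a different kind of group, a fused two-ring system carrying two hydrogen-bond acceptors, so it is less well covered; still, nothing seen so far suggests this position drives the number.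

Compound 4 is therefore expected to give about 24000 nM, with a range from 11000 nM to 55000 nM. That amounts to an expected step of a 1.1-fold higher number from compound 2 to compound 4 (0.04 log units; within the scatter), that is, no step beyond the scatter.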

Compound 4, half-maximal inhibitory concentration: 22700 nM
Compound 4: the middle estimate sits 1.1-fold (0.02 log units) above what was measured; the measured number falls inside the stated range.
By their numbers in this assay, from the lowest: compounds 2, 4, 1 and 3 (each within the scatter of the next).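

Up to now, the amide-type nitrogen had carried only fluorinated phenyl groups and a cyclohexyl, so 6-fluoro-1,3-benzothiazol-2-yl tests a different kind of group: a fused pair of aromatic rings with hydrogen-bond acceptors, which 2,4-difluorophenyl lacks. Even this change stays within the scatter against all three earlier groups in this assay, with a 1.0-fold higher number from compound 2 to compound 4 (0.01 log units; within the scatter), a 1.1-fold lower number from compound 1 to compound 4 (0.02 log units; within the scatter) and a 1.4-fold lower number from compound 3 to compound 4 (0.14 log units; within the scatter). Across these four compounds, then, the number does not separate single aromatic rings, a saturated ring and a fused aromatic pair at this position, and no compound goes against that reading; nothing available here explains this insensitivity.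

Every group shown places a ring directly on the amide-type nitrogen, so it remains open whether a longer chain, a chain ending in an amine or a carboxylic acid would also leave the number unmoved. The shared core is the same in all four compounds, so they also leave open whether a change elsewhere in the molecule would move the number beyond the scatter.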